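Series notes: amino to (cyanomethyl)sulfanyl on the shared core

This account rests on a few compounds, and the source may have more. Where it says the series, first, only, none or still open, it means among the compounds named here.

Of the compounds shown here, three have been measured in a functional assay on HeLa cells (Homo sapiens) for antiproliferative activity, read by MTT assay, with a stated time of 48 h; a lower number here means a stronger inhibitor, a higher number a weaker inhibitor. Compound 1 `Cc1ccc(-c2nc3ccc(Cl)cc3c(=S)[nH]2)cc1` gives 4.57 ug/mL. Compound 2 `Cc1ccc(-c2nc(N)c3cc(Cl)ccc3n2)cc1` gives 3.56 ug/mL. Compound 3 `Cc1ccc(C(=O)Nc2ccc(Cl)cc2C(=S)NN)cc1` gives 4.98 ug/mL. Compound 2 stands at the lowest of the three numbers, but its gaps to compound 1 and to compound 3 both fall within the scatter, so no order among the three can be read from these values. Within the data shown here, no two of the measured compounds differ in a single place, so no single-point step is available from them.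

Compound 4 `Cc1ccc(-c2nc(SCC#N)c3cc(Cl)ccc3n2)cc1` is not yet measured. It differs from compound 2 in one place: (cyanomethyl)sulfanyl in place of amino on an aromatic carbon. Among the measured compounds shown here, nothing measured so far shows what this exchange does on the shared core, and none of the three known numbers involves the (cyanomethyl)sulfanyl group. With no shown step to lean on, the expected step of a 1.1-fold higher number from compound 2 to compound 4 (0.05 log units; within the scatter) is none beyond the scatter, in either direction. Compound 4 is therefore expected to give 4 ug/mL in this assay, with an estimated range from 1.5 ug/mL to 12 ug/mL. The range is kept wide since compound 2 at 3.56 ug/mL is the only anchor for it.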

Compound 4, half-maximal inhibitory concentration: 3.76 ug/mL
Compound 4: middle estimate off by 1.1-fold (0.03 log units), on the high side, within the range that was stated.
By their numbers in this assay, from the lowest: compounds 2, 4, 1 and 3 (each within the scatter of the next).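

In this assay, among these compounds, the exchange of amino for (cyanomethyl)sulfanyl on the aromatic carbon next to the ring nitrogen gives the first single-place comparison: a 1.1-fold higher number from compound 2 to compound 4 (0.02 log units; within the scatter). At this position, a group of 1 heavy atom with 1 hydrogen-bond donor gives way to one of 4 heavy atoms with 0 hydrogen-bond donors and a triple bond, and the two compounds cannot be told apart in this assay, so this one pair shows that the position accepts this exchange without a difference beyond the scatter. No measurement of any property of these compounds is at hand to explain this result.

One pair cannot show whether the position is indifferent to its substituent in general, or whether other groups there, such as a carboxylic acid, a simple methylsulfanyl group or a longer chain ending in the nitrile, would move the number beyond the scatter. As far as these compounds go, it also remains open whether the same exchange would give a similar result on a different core or in another cell line.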